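The source may report more compounds than this note shows. Statements on the series, on what has been measured and on what is new or still open speak of the compounds shown alone.

Among the compounds with values here, in a functional assay on A549 cells (Homo sapiens) for cytotoxicity, read by MTT assay, with a stated time of 48 h (on this read-out lower numbers stand for stronger inhibition and higher numbers for weaker inhibition), two compounds built on the shared core have numbers so far. Compound 1 (`CCOC(=O)[C@]1(C(=O)Nc2ccccc2)C[C@@H]1c1cc(OC)c(OC)c(OC)c1`) gives 21300 nM. Compound 2 (`COc1cc([C@H]2C[C@]2(CO)C(=O)NCc2ccc(C)cc2)cc(OC)c1OC`) gives 60700 nM, the higher of the two numbers and thus the weaker inhibition, and its gap to compound 1 lies beyond the usual scatter. These two compounds differ in more than one place, so their gap cannot be tied to any single group. Compound 3 (`CCOC(=O)[C@]1(C(=O)NCc2ccc(C)cc2)C[C@@H]1c1cc(OC)c(OC)c(OC)c1`) keeps the amide of compound 2 but has ethoxycarbonyl in place of hydroxymethyl on a saturated ring carbon. Within the data shown here, no measured pair shows this change alone. Among the measured compounds shown here, the only guide is compound 1, which carries ethoxycarbonyl on that ring carbon, with a different amide, and gives 21300 nM. A moderate step towards a lower number is therefore expected in this assay, around the edge of the scatter. The estimated change is a 2.0-fold lower number from compound 2 to compound 3 (0.31 log units; beyond the scatter). For compound 3 the expected value is 30000 nM, with an estimated range of 11000 nM to 70000 nM.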

Compound 3, half-maximal inhibitory concentration: 34900 nM
The estimate for compound 3 lay 1.2-fold (0.07 log units) below the measured number; the range from low to high includes it.
By their numbers in this assay, from the lowest: compounds 1, 3 and 2 (each within the scatter of the next, the first and the last beyond it).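

In this assay, ethoxycarbonyl in place of hydroxymethyl on a saturated ring carbon can now be read as a single change, and with the 4-methylbenzyl amide held constant it gives a step that does not separate the pair (a 1.7-fold lower number from compound 2 to compound 3 (0.24 log units; within the scatter)), even though the entering group has more heavy atoms and no hydrogen-bond donor. Compound 3 also provides the first reading on the amide-type nitrogen with ethoxycarbonyl held on the ring carbon, and 4-methylbenzyl in place of phenyl likewise stays unresolved (a 1.6-fold higher number from compound 1 to compound 3 (0.21 log units; within the scatter)), so neither single change shown here can be told from the scatter in this assay. Nothing at hand gives a reason for these numbers.

On these data alone, it remains open whether a carboxylic acid, an aminomethyl group or a longer ester chain on that ring carbon would move the number clearly away from those of hydroxymethyl and ethoxycarbonyl. Also open, as far as these compounds go, is how hydroxymethyl behaves with the phenyl amide, the pairing that would show whether the two small steps add up, and whether a plain benzyl or a chlorobenzyl group on the amide nitrogen would read any differently.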